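The source may report more compounds than this note shows. Statements on the series, on what has been measured and on what is new or still open speak of the compounds shown alone.

Working notes on the series. Read-out for all members: a functional assay on the whole organism with Rattus norvegicus as the target, at a dose of 40 mg/kg by the intraperitoneal route; on this read-out lower numbers stand for less inhibition and higher numbers for more inhibition at the one dose given (going by the name of the read-out). Compound 1, `Cc1nc2c(CCc3ccccc3)cccn2c1N`, gives 47% in this assay, the lowest of the three numbers; compound 2, `Cc1nc2c(OCc3ccccc3)cccn2c1/N=C/N(C)C`, gives 64%, a number beyond the scatter above compound 1, and compound 3, `CCNc1c(C)nc2c(OCc3ccccc3)cccn12`, gives 95%, the furthest from compound 1, also beyond the scatter. Within the data shown here, the one step between compounds differing in one place is a number 31 percentage points higher from compound 2 to compound 3 (beyond the scatter) in this assay, a group of 3 heavy atoms in place of a group of 5 heavy atoms on an aromatic carbon; it exchanges one non-ring group for another and does not show an exchange of the atom joined to the ring.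

Compound 4 is `Cc1nc2c(CCc3ccccc3)cccn2c1O`; against compound 1 the change is hydroxy in place of amino on an aromatic carbon. Among the measured compounds shown here, no measured step shows hydroxy in place of amino, so nothing in the data sets a size or direction for this step, and the expectation rests on compound 1 alone with a wide range. For compound 4 the step of a number 7 percentage points lower from compound 1 to compound 4 (within the scatter) in this assay is estimated, within the scatter as its centre. Compound 4 is thus expected to give 40% in this assay, in the range 12% to 68%.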

Compound 4, a percentage reported as inhibition, in the whole organism at one dose (the size of the read-out at that dose, not a potency): 32%
Estimate against measurement, compound 4: 8 percentage points above; the measured number falls inside the stated range.
By their numbers in this assay, from the lowest: compound 4; then compound 1; then compound 2; then compound 3.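

In this assay, the change of the atom joined to the ring, which the earlier step did not show, gives a number 15 percentage points lower from compound 1 to compound 4 (beyond the scatter). This exchange of one group for another on the aromatic carbon of the five-membered ring therefore registers in the read-out, even though amino and hydroxy match in the computed counts of heavy atoms, hydrogen-bond donors and hydrogen-bond acceptors. No measurement at hand offers an explanation for this difference.

On these data alone, the step is read only on the core of compound 1, so whether hydroxy in place of amino has a similar effect on the core of compound 3 remains open. As far as these compounds go, how a methoxy group or a carboxylic acid at this position would compare with amino and hydroxy also remains open.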